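The source may hold more compounds than are shown below. What is called first, only, known or untested is meant among the compounds shown, and "the series" means these compounds.

Compound 2 `CC1(C)C=C(n2ccccc2=O)c2cc(S(=O)(=O)NCCO)ccc2O1` carries a 2-hydroxyethyl group on its sulfonamide nitrogen. In a functional assay on the whole organism (aorta) with Rattus norvegicus as the target (a higher number here means a larger maximal response, a lower number a smaller maximal response), compound 2 gives 95.5%, the highest of the two single numbers available. Nearest stands compound 1 `CNS(=O)(=O)c1ccc2c(c1)C(n1ccccc1=O)=CC(C)(C)O2`, which in this assay gives 85.8%, so the step of a number 9.7 percentage points higher from compound 1 to compound 2 (within the scatter). Compound 3 `CC1(C)C=C(n2ccccc2=O)c2cc(S(=O)(=O)Nc3ccccc3)ccc2O1`, with a plain phenyl on the same nitrogen, has two entries in this assay rather than one number, and these repeat readings the several entries of compound 3 in this assay, 63.6%; 82.5% (2 entries) show how far two measurements of one compound can lie apart. Compound 4 `CC1(C)C=C(n2ccccc2=O)c2cc(S(=O)(=O)Nc3ccc(C#N)cc3)ccc2O1` is not yet measured. The change from compound 2 to compound 4 is 4-cyanophenyl in place of 2-hydroxyethyl on a sulfonamide nitrogen. No measured step covers this swap; the only step shown, on the other side of compound 2, stayed within the scatter. Compound 3 bears on it in that a phenyl on this nitrogen gave 63.6%; 82.5% (2 entries), both entries lying below the number for compound 2. Compound 4 is therefore expected to sit somewhat lower, an expected step of a number 20.5 percentage points lower from compound 2 to compound 4 (beyond the scatter). The estimate for compound 4 is 75%, ranging from 55% to 95%.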

Compound 4, largest response reached (Emax), in percent of the reference or control that the assay uses: 84%
For compound 4 the middle estimate is 9 percentage points below the measured one, and the stated range covers the measured number.
By their numbers in this assay, from the lowest: compounds 4, 1 and 2 (each within the scatter of the next, the first and the last beyond it).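

Replacing 2-hydroxyethyl with 4-cyanophenyl on the sulfonamide nitrogen costs only part of the response in this assay, giving a number 11.5 percentage points lower from compound 2 to compound 4 (beyond the scatter). Measured against the small methyl group, the same aromatic group gives a number 1.8 percentage points lower from compound 1 to compound 4 (within the scatter), so this nitrogen accepts a group of 8 heavy atoms with 0 hydrogen-bond donors and still retains a large maximal response. What the nitrile itself contributes cannot be settled against the plain phenyl of compound 3, whose repeat readings lie far apart: the several entries of compound 3 in this assay, 63.6%; 82.5% (2 entries).

From the compounds shown here alone, it remains open how a carboxylic acid or an amine at the end of the chain would compare with the hydroxyl of compound 2. A longer chain on this nitrogen, or a phenyl ring carrying chlorine or methoxy instead of the nitrile, also remains to be compared.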